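Isopropyl in place of hydrogen on a core at the limit

The source may report more compounds than this note shows. Statements on the series, on what has been measured and on what is new or still open speak of the compounds shown alone.

Measured compounds:
Compound 1, `CCCc1nc(C)c2cnnc(O)n12`: in a functional assay for inhibition, with Homo sapiens as the target (on this read-out higher numbers stand for weaker inhibition and lower numbers for stronger inhibition), compound 1 gives 56800 nM.
Compound 2, `Cc1nc(C(C)C)n2c(O)nnc(-c3ccccc3)c12`: in this assay compound 2 gives > 48000 nM, which is a limit of the assay and not a number.
Compound 3, `Cc1ncn2c(O)nncc12`: in this assay compound 3 gives > 48000 nM, again a limit of the assay.

Compound 3 thus stands on a limit only, and one further value in the set is a limit as well, as the limit of > 48000 nM in this assay, at which 2 of the 3 values shown sit, records. Going by the values given here, its single direct comparison, a step that the limit leaves unreadable from compound 1 to compound 3, cannot be sized, the end point being a limit. Compound 4, `Cc1nc(C(C)C)n2c(O)nncc12`, differs from compound 3 by isopropyl in place of hydrogen on an aromatic carbon. Compound 2 also carries an isopropyl group, and in this assay compound 2 sits at the limit. Among the compounds with values here, no measured step bears on this change with a readable size. Compound 4 is therefore expected to remain at or near the limit in this assay, the step that the limit leaves unreadable from compound 3 to compound 4 being expected to show nothing beyond the scatter. The estimate for compound 4 is 60000 nM, with a range from 20000 nM to 200000 nM.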

Compound 4, half-maximal inhibitory concentration: > 48000 nM
Compound 4: only a limit was reported; the forecaster's own chance of this, stated with the estimate: 70%; the middle value lies beyond the limit too.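

In this assay compound 4 gives > 48000 nM, which is a limit of the assay and not a number. None of its steps from compound 1, compound 2 or compound 3 can be read. The compounds shown leave open what any of these changes does to inhibition, as most of them rest on a single mark: the limit of > 48000 nM in this assay, at which 3 of the 4 values shown sit.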